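Swapping the fluorophenyl of compound 3 for a dichlorophenyl

The source may hold more compounds than are shown below. What is called first, only, known or untested is meant among the compounds shown, and "the series" means these compounds.

Of the compounds shown here, three have been tested in a functional assay on MOLT-4 cells (Homo sapiens); a higher number here means a weaker inhibitor, a lower number a stronger inhibitor. Compound 1 `O=C(/C=C/c1ccc(Cl)c(Cl)c1)Oc1ccc(/C=C2\CCCCC2=O)cc1` gives 47300 nM in this assay, and compound 2 `CN(C)CC1CCC/C(=C\c2ccc(OC(=O)/C=C/c3ccccc3)cc2)C1=O` gives 39500 nM. Compound 3 `CN(C)CC1CCC/C(=C\c2ccc(OC(=O)/C=C/c3ccc(F)cc3)cc2)C1=O` gives 3780 nM, the lowest of the three numbers, and its separation from both other compounds lies beyond the scatter. Among the measured compounds shown here, the single one-place step among them is a 10-fold lower number from compound 2 to compound 3 (1.02 log units; beyond the scatter).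

Compound 4 `CN(C)CC1CCC/C(=C\c2ccc(OC(=O)/C=C/c3ccc(Cl)c(Cl)c3)cc2)C1=O` differs from compound 3 in one place: 3,4-dichlorophenyl in place of 4-fluorophenyl on a double-bonded chain carbon bound to a double-bonded chain carbon. For the measured compounds named here, no measured step covers this exact change. Going by the values given here, the only step that bears on the site, the one from compound 2 to compound 3, shows that substitution on this ring can move the number considerably. Among the compounds with values here, compound 1 carries the 3,4-dichlorophenyl group but on a different core, so its value of 47300 nM shows only that this group sits on a weak compound there; the values of compound 1 and compound 3 cannot be read as a step. Given this, the expected step is a 2.6-fold higher number from compound 3 to compound 4 (0.42 log units; beyond the scatter), a modest loss with wide uncertainty. Compound 4 is therefore estimated at 10000 nM, within a range of 2000 nM to 50000 nM.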

Compound 4, half-maximal inhibitory concentration: 4570 nM
Compound 4: middle estimate off by 2.2-fold (0.34 log units), on the high side, and the stated range covers the measured number.
By their numbers in this assay, from the lowest: compounds 3 and 4 (each within the scatter of the next); then compounds 2 and 1 (each within the scatter of the next).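

In this assay, replacing 4-fluorophenyl with 3,4-dichlorophenyl gives a 1.2-fold higher number from compound 3 to compound 4 (0.08 log units; within the scatter), so at this place on the shared core the two substituted rings cannot be told apart. Among the compounds shown here, measured against the phenyl of compound 2, the dichlorinated ring gives an 8.6-fold lower number from compound 2 to compound 4 (0.94 log units; beyond the scatter), which lies beyond the scatter, and the same 3,4-dichlorophenyl group with (dimethylamino)methyl in place of hydrogen on a saturated ring carbon gives a 10-fold lower number from compound 1 to compound 4 (1.01 log units; beyond the scatter), the first one-place reading of that side chain. No measurement among the data shown accounts for any of these steps.

The compounds shown leave open whether a ring carrying a methoxy group, a nitrile or a single chlorine at this place would stay level with compound 3 and compound 4 or fall back towards compound 2. They also leave open whether the (dimethylamino)methyl step would recur with the phenyl or 4-fluorophenyl ring, and whether a morpholine in place of the dimethylamino group would keep it.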